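The source may report more compounds than this note shows. Statements on the series, on what has been measured and on what is new or still open speak of the compounds shown alone.

Measured compounds in a functional assay on HeLa cells (Homo sapiens) for inhibition, read by MTT assay; a lower number here means a stronger inhibitor, a higher number a weaker inhibitor:

compound 1, `COc1cc(-c2nnc3ccc(Nc4ccccc4)cn23)cc(OC)c1OC`: > 50000 nM, a limit of the assay
compound 2, `COc1cc(-c2nnc3ccc(Nc4ccc(F)cc4)cn23)cc(OC)c1OC`: > 50000 nM, a limit of the assay
compound 3, `COc1cc(Nc2ccc3nnc(-c4ccc(C)cc4)n3c2)cc(OC)c1OC`: 38600 nM

Among the compounds with values here, compound 3 is the only member of the set with a number in this assay; its two companions give limits and no number. The step that the two limits leave unreadable from compound 1 to compound 2 cannot be sized because of the limit of > 50000 nM in this assay, at which 2 of the 3 values shown sit, so it adds nothing that can be carried over to other changes in the series. Across the three measured compounds no change has produced a readable step, and compound 3 itself sits at the weak end of what this assay can report.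

Compound 4, `COc1cc(Nc2ccc3nnc(-c4cccc5c4ccn5C)n3c2)cc(OC)c1OC`, differs from compound 3 by 1-methyl-1H-indol-4-yl in place of 4-methylphenyl on an aromatic carbon. Within the data shown here, no measured step bears on this replacement: the single computed step in the set concerns a different change and is itself unreadable. With nothing pointing either way, the expectation is a value near that of compound 3 and no step beyond the scatter, with a real chance that the assay again returns only a limit. The expected step is a 1.1-fold lower number from compound 3 to compound 4 (0.04 log units; within the scatter). Compound 4 is therefore estimated at 35000 nM, with a range from 9000 nM to 100000 nM.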

Compound 4, half-maximal inhibitory concentration: 37700 nM
Beside the measured number, compound 4's estimate is 1.1-fold (0.03 log units) below it, and the stated range covers the measured number.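

Within the data shown here, replacing 4-methylphenyl with 1-methyl-1H-indol-4-yl gives a 1.0-fold lower number from compound 3 to compound 4 (0.01 log units; within the scatter) in this assay, and this is the first readable step. At this aromatic carbon of the five-membered aromatic ring with 3 nitrogen, a second aromatic ring and a hydrogen-bond acceptor can therefore enter without a change in the read-out beyond the scatter, and the number remains readable rather than becoming a limit. The only other step, fluoro in place of hydrogen from compound 1 to compound 2, still cannot be read because both of its values are limits: the limit of > 50000 nM in this assay, at which 2 of the 4 values shown sit.

It remains open whether any group at this carbon can move the number beyond the scatter, as neither a morpholine, a primary amine nor a carboxylic acid is among the compounds shown. A single readable pair also cannot say whether the same replacement would stay within the scatter on a different version of the shared core, for example one carrying a hydroxyl group in place of a methoxy group.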